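This account rests on a few compounds, and the source may have more. Where it says the series, first, only, none or still open, it means among the compounds named here.

Measured so far:
compound 1, `CCO/C(O)=C1\C(COCCn2c(C)nc(C)c2C)=NC(C)=C(C(=O)Nc2ccccc2)C1c1ccccc1Cl`, in a functional assay on the whole organism for antagonist activity, with Mus sp. as the target (on this read-out higher numbers stand for an effect only at larger amounts of compound and lower numbers for an effect already at smaller amounts), compound 1 gives 18 mg/kg
compound 2, `CCO/C(O)=C1\C(COCCn2c(C)nc(C)c2C)=NC(C)=C(C(=O)NC(C)(C)C)C1c1ccccc1Cl`, in this assay compound 2 gives 10.1 mg/kg

Within the data shown here, compound 2 stands at the lowest of the two numbers, with compound 1 nearest; the gap between them is the single measured step, a 1.8-fold lower number from compound 1 to compound 2 (0.25 log units; within the scatter), and it stays within the scatter, so no order between the two is claimed.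

Compound 3, `CCO/C(O)=C1\C(COCCn2c(C)nc(C)c2C)=NC(C)=C(C(=O)Nc2cccc(C)n2)C1c1ccccc1Cl`, is reached from compound 2 by 6-methylpyridin-2-yl in place of tert-butyl on an amide-type nitrogen.

Among the measured compounds shown here, only one measured step touches the same place: a 1.8-fold lower number from compound 1 to compound 2 (0.25 log units; within the scatter), an exchange of one group for another on the amide-type nitrogen that did not move this assay beyond the scatter. The group entering in compound 3 is, like the group of compound 1, a six-membered aromatic ring on that nitrogen, so the number for compound 3 is expected to lie near the two measured values rather than outside them; the expected step is a 1.4-fold higher number from compound 2 to compound 3 (0.14 log units; within the scatter), not beyond the scatter. Compound 3 is therefore estimated at 14 mg/kg in this assay, with a range from 6 mg/kg to 35 mg/kg.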

Compound 3, dose for half-maximal effect: 4.5 mg/kg
The estimate for compound 3 lay 3.1-fold (0.49 log units) above the measured number; the whole stated range lies above it.
By their numbers in this assay, from the lowest: compound 3; then compounds 2 and 1 (each within the scatter of the next).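

The amide-type nitrogen is now shown to be a place where an exchange can move the number beyond the scatter in this assay: 6-methylpyridin-2-yl in place of tert-butyl gives a 2.2-fold lower number from compound 2 to compound 3 (0.35 log units; beyond the scatter), whereas the earlier exchange at this place stayed within it. A six-membered aromatic ring on this nitrogen does not by itself fix the number, since 6-methylpyridin-2-yl in place of phenyl gives a 4.0-fold lower number from compound 1 to compound 3 (0.60 log units; beyond the scatter); that change brings in a ring nitrogen and a methyl group together, and the step reflects the two as one exchange. No measurement at hand explains why either step takes this direction or this size.

Still open, on these data alone, is which part of 6-methylpyridin-2-yl carries the step, a question that a pyridin-2-yl group without the methyl would address on the same core. Also open, as far as these compounds go, is how far the trend extends at this nitrogen, for example to a pyridine ring bearing an ethyl group or an amine in place of the methyl, or to a longer alkyl chain.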